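The source may report more compounds than this note shows. Statements on the series, on what has been measured and on what is new or still open speak of the compounds shown alone.

Three compounds share one core, and only one of them carries a number. Compound 1, `Cc1cn2c(-c3cn[nH]c3)cnc2c(Nc2cc(Cn3cccc3)ns2)n1`, stands in an ADME assay on Caco-2 cells (Homo sapiens) for permeability, in the apical to basolateral direction (a higher number here means that the compound crosses the layer faster, a lower number that the compound crosses the layer more slowly), as "not determined" (no result reported), so nothing can be said about how it crosses a cell layer. Compound 2, `Cc1cn2c(-c3cn[nH]c3)cnc2c(Nc2cc(Cc3ncccn3)ns2)n1`, likewise stands in this assay as "not determined" (no result reported), and nothing can be said about it either. For the measured compounds named here, compound 3, `Cc1cn2c(-c3cn[nH]c3)cnc2c(Nc2cc(Cc3ccccn3)ns2)n1`, is the sole compound with a measurement: in this assay compound 3 gives 28 nm/s. Within the set shown, compound 3 therefore stands alone, and no comparison with a neighbour is possible.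

Compound 4, `Cc1cn2c(-c3cn[nH]c3)cnc2c(Nc2cc(C(NC(C)(C)C)c3ccccn3)ns2)n1`, has not yet been measured. It differs from compound 3 in exactly one place: (tert-butyl)amino in place of hydrogen on a saturated chain carbon bound to two aromatic carbons. The rest of the molecule, including the core and the pyridinyl-bearing side, is unchanged.

Going by the values given here, no pair of measured compounds differing in one place exists here. Among the compounds with values here, there is thus no known step to lean on. The change from compound 3 to compound 4 adds a donor and an acceptor at one carbon, and in the absence of any measured precedent the expectation is a small shift, probably downward and likely within or just beyond the usual scatter, as an estimate of a 1.6-fold lower number from compound 3 to compound 4 (0.19 log units; within the scatter) expresses. Taken together, compound 4 is expected to give about 18 nm/s in this assay, with a plausible range from 6 nm/s to 55 nm/s.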

Compound 4, apparent permeability: 24 nm/s
Compound 4: middle estimate off by 1.3-fold (0.12 log units), on the low side; low and high end bracket the measured number.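

In this assay, (tert-butyl)amino in place of hydrogen on a saturated chain carbon bound to two aromatic carbons gives a 1.2-fold lower number from compound 3 to compound 4 (0.07 log units; within the scatter) and so leaves the two compounds indistinguishable in this read-out. For the compounds shown here, this is the first reading for any change at this carbon: it can carry a group of 5 heavy atoms with a hydrogen-bond donor and a hydrogen-bond acceptor, and the number that results cannot be separated from that of the compound with hydrogen there. No independent measurement is available to explain this outcome.

As far as these compounds go, with a single step at this carbon, no general rule can be drawn, and it remains open whether a much smaller amine such as methylamino, or a carboxylic acid, would give a number just as close to that of compound 3. From the compounds shown here alone, it is also open whether (tert-butyl)amino would behave the same way if a ring other than the pyridinyl group were attached to this carbon.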